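The source may report more compounds than this note shows. Statements on the series, on what has been measured and on what is new or still open speak of the compounds shown alone.

Measured so far in a functional assay on MCF7 cells (Homo sapiens) for cytotoxicity, read by MTT assay, with a stated time of 72 h; a higher number here means a weaker inhibitor, a lower number a stronger inhibitor:
- Compound 1, `CCCCCCCCNc1nc(SCc2ccc(C(F)(F)F)cc2)nc2ccccc12`: 26100 nM
- Compound 2, `Cc1ccccc1Nc1nc(SCc2ccc(C(F)(F)F)cc2)nc2ccccc12`: 37500 nM
- Compound 3, `CCOc1ccc(Nc2nc(SCc3ccc(C(F)(F)F)cc3)nc3ccccc23)cc1`: > 50000 nM, which is a limit of the assay rather than a number.

Compound 1 carries the smaller of the two numbers, but the gap to compound 2, a 1.4-fold higher number from compound 1 to compound 2 (0.16 log units; within the scatter), is within the scatter, so the two cannot be ranked. For compound 3 only the limit of > 50000 nM in this assay, at which 1 of the 3 values shown sits, is known.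

Compound 4, `Fc1ccc(Nc2nc(SCc3ccc(C(F)(F)F)cc3)nc3ccccc23)cc1Cl`, has not been measured. It differs from compound 1 as follows: 3-chloro-4-fluorophenyl in place of octyl on a nitrogen on an aromatic ring.

Within the data shown here, two measured steps bear on this change, both swapping the octyl chain for a ring on the same nitrogen: a 1.4-fold higher number from compound 1 to compound 2 (0.16 log units; within the scatter) and an at least 1.9-fold higher number from compound 1 to compound 3 (0.28 log units; that floor lies within the scatter). Neither rises clearly above the scatter, yet both point the same way, toward a higher number. A similar small upward step is therefore expected for compound 4, with a fair chance that the assay reports only a limit.

Compound 4 is estimated at 40000 nM, within a range from 18000 nM to 90000 nM. This estimate corresponds to an expected step of a 1.5-fold higher number from compound 1 to compound 4 (0.19 log units; within the scatter).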

Compound 4, half-maximal inhibitory concentration: 23000 nM
Compound 4: the middle estimate sits 1.7-fold (0.24 log units) above what was measured; the measured number falls inside the stated range.
By their numbers in this assay, from the lowest: compounds 4, 1 and 2 (each within the scatter of the next). At a limit, above all of these: compound 3.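

In this assay, putting an aromatic ring on this nitrogen does not by itself raise the number, as compound 4 shows against both its neighbours: a 1.1-fold lower number from compound 1 to compound 4 (0.05 log units; within the scatter) and a 1.6-fold lower number from compound 2 to compound 4 (0.21 log units; within the scatter). Among these compounds, compound 4 therefore cannot be ranked against the octyl compound 1 or the 2-methylphenyl compound 2, and the upward drift seen in the earlier steps does not hold for every ring. The one step beyond the scatter lies between two substituted phenyl rings, an at least 2.1-fold lower number from compound 3 to compound 4 (0.33 log units; beyond the scatter), so what the ring carries can matter at this position, although this step is read against a limit and compound 3 has no exact number: the limit of > 50000 nM in this assay, at which 1 of the 4 values shown sits.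

Whether the chlorine or the fluorine of the 3-chloro-4-fluorophenyl group accounts for that step stays open, since the compounds shown do not separate them. Also open, from the compounds shown here alone, is whether a shorter chain, or a chain ending in an amine or a carboxylic acid, on this nitrogen would give a number clearly lower than those of compound 1 and compound 4.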